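This account rests on a few compounds, and the source may have more. Where it says the series, first, only, none or still open, it means among the compounds named here.

Measured in a functional assay on Jurkat cells (Homo sapiens) for inhibition, read by CCK-8 assay, with a stated time of 48 h; a lower number here means a stronger inhibitor of growth, a higher number a weaker inhibitor of growth:
- Compound 1 `Cc1ccccc1Nc1nc(Nc2ccccc2)ncc1Cl`: > 100000 nM, which is a limit of the assay and not a number.
- Compound 2 `Cc1ccccc1Nc1nc(Nc2ccc(N3CCN(C)CC3)cc2)ncc1Cl`: 13700 nM
- Compound 3 `CCN1CCN(c2ccc(Nc3ncc(Cl)c(Nc4ccccc4C)n3)cc2)CC1`: 2060 nM

Among these, compound 3 has the lowest number, and compound 2 is its nearest neighbour. The next compound, compound 4 `Cc1ccccc1Nc1nc(Nc2ccc(N3CCN(C(=O)OC(C)(C)C)CC3)cc2)ncc1Cl`, carries tert-butoxycarbonyl in place of ethyl on an amine nitrogen in a ring. For the measured compounds named here, two measured steps bear on this change. The closest is at the same end of the molecule, where methyl in place of hydrogen on the saturated chain carbon gave a 6.7-fold lower number from compound 2 to compound 3 (0.82 log units; beyond the scatter). The other, an at least 48-fold lower number from compound 1 to compound 3 (1.68 log units; beyond the scatter), is counted from the limit of > 100000 nM in this assay, at which 1 of the 3 values shown sits, so it gives only a minimum size for what the whole 4-ethylpiperazin-1-yl group contributes. Neither step tests a group of the kind entering here, so they offer only a loose guide. Since the step to compound 3 shows that a small change on this part can move the number well beyond the scatter, a modest step is expected in this assay, more likely towards a higher number than a lower one. The expected change is a 2.9-fold higher number from compound 3 to compound 4 (0.46 log units; beyond the scatter). For compound 4 the estimated value is 6000 nM, with an expected range from 1200 nM to 30000 nM.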

Compound 4, concentration for 50% growth inhibition: 5120 nM
For compound 4 the middle estimate is 1.2-fold (0.07 log units) above the measured one, and the stated range covers the measured number.
By their numbers in this assay, from the lowest: compound 3; then compound 4; then compound 2. At a limit, above all of these: compound 1.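

In this assay, the amine nitrogen in the ring accepts a far larger group than methyl or ethyl with only a 2.5-fold higher number from compound 3 to compound 4 (0.40 log units; beyond the scatter) on going to tert-butoxycarbonyl, and the number stays in the same low range as those of the two alkyl compounds. The same exchange measured against methyl gives a 2.7-fold lower number from compound 2 to compound 4 (0.43 log units; beyond the scatter), so compound 4 falls between the two alkyl compounds, and the earlier fall in the number from methyl to ethyl does not extend into a simple rule that a larger group here gives a lower number, with compound 4 going against it. Compound 1, with hydrogen in place of the whole group, stands at a limit and not a number, and any comparison with it gives only a minimum: the limit of > 100000 nM in this assay, at which 1 of the 4 values shown sits.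

The carbonyl and the tert-butyl part enter together in compound 4, so the compounds shown do not separate what each contributes. Still open, from the compounds shown here alone, is how the number responds to a longer chain such as propyl, to an acetyl group, or to a plain hydrogen on this nitrogen.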